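Chloro for Methyl: Carrying a Measured Step to Compound 4

The source may report more compounds than this note shows. Statements on the series, on what has been measured and on what is new or still open speak of the compounds shown alone.

In a functional assay on HeLa cells (Homo sapiens) for inhibition, read by sulforhodamine B assay, with a stated time of 48 h (on this read-out lower numbers stand for stronger inhibition of growth and higher numbers for weaker inhibition of growth), the three measured compounds fall within a narrow band. Compound 1 `COC(=O)[C@@]1(C)CCC=C2[C@@H]1CC[C@@H](C)[C@]2(C)Cc1c[nH]c2c(C)cccc12` gives 4900 nM, compound 2 `COC(=O)[C@@]1(C)CCC=C2[C@@H]1CC[C@@H](C)[C@]2(C)Cc1c[nH]c2c(Br)cccc12` gives 13000 nM, and compound 3 `COC(=O)[C@@]1(C)CC[C@@H]2C3=C1CC[C@@H](C)[C@]3(C)C[C@@H]1c3cc(C)ccc3N[C@H]21` gives 18000 nM. Compound 3 thus carries the highest number of the three: its gap to compound 2 lies within the scatter, while its gap to compound 1 lies beyond it. Compound 4 `COC(=O)[C@@]1(C)CC[C@@H]2C3=C1CC[C@@H](C)[C@]3(C)C[C@@H]1c3cc(Cl)ccc3N[C@H]21` differs from compound 3 by chloro in place of methyl on an aromatic carbon. Among the measured compounds shown here, one measured step bears on this change: a 2.7-fold higher number from compound 1 to compound 2 (0.42 log units; beyond the scatter), where likewise a methyl on an aromatic carbon gave way to a halogen, and the number rose modestly. A rise of similar, modest size is therefore expected here, though it may not stand clearly beyond the scatter. For compound 4 the expected step is a 1.6-fold higher number from compound 3 to compound 4 (0.19 log units; within the scatter). For compound 4 the estimate in this assay is 28000 nM, with a range from 12000 nM to 65000 nM.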

Compound 4, concentration for 50% growth inhibition: 23000 nM
Estimate against measurement, compound 4: 1.2-fold (0.09 log units) above, within the range that was stated.
By their numbers in this assay, from the lowest: compound 1; then compounds 2, 3 and 4 (each within the scatter of the next).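

On this aromatic carbon of the five-ring core, chloro can replace methyl with only a 1.3-fold higher number from compound 3 to compound 4 (0.11 log units; within the scatter) in this assay, so the two compounds cannot be told apart in this assay. Among the compounds shown here, the only earlier halogen-for-methyl step, a 2.7-fold higher number from compound 1 to compound 2 (0.42 log units; beyond the scatter), lay beyond the scatter, but it involved bromo rather than chloro and a different core, so a halogen in place of methyl need not shift the number by a clear margin. Nothing measured here gives a reason for this result.

The compounds shown leave open what an amine, a carboxylic acid or a longer chain on this same aromatic carbon would do in this assay. They also leave open how chloro would compare with methyl and bromo on the core of compound 1.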